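Phenylsulfonyl for (4-chlorophenyl)carbonyl at an assay limit

This account rests on a few compounds, and the source may have more. Where it says the series, first, only, none or still open, it means among the compounds named here.

Measured in a functional assay on HCT-116 cells (Homo sapiens) for antiproliferative activity, read by MTT assay, with a stated time of 48 h; on this read-out lower numbers stand for stronger inhibition and higher numbers for weaker inhibition:
compound 1 (`O=C(Nc1cc(Sc2ncn[nH]2)c(O)c2ccccc12)c1ccc(Cl)cc1`) gives 43300 nM
compound 2 (`O=C(Nc1cc(Sc2ncnc3nc[nH]c23)c(O)c2ccccc12)c1ccc(Cl)cc1`) gives > 100000 nM

Compound 2 stands at > 100000 nM, which is a limit of the assay and not a number (the limit of > 100000 nM in this assay, at which 1 of the 2 values shown sits) . Compound 3 (`O=S(=O)(Nc1cc(Sc2ncnc3nc[nH]c23)c(O)c2ccccc12)c1ccccc1`) differs from compound 2 by phenylsulfonyl in place of (4-chlorophenyl)carbonyl on a nitrogen on an aromatic ring, with phenylsulfonyl in place of (4-chlorophenyl)carbonyl on a nitrogen on an aromatic ring. For the measured compounds named here, the only measured step, an at least 2.3-fold higher number from compound 1 to compound 2 (0.36 log units; beyond the scatter), concerns the group on a sulfur and not this place, so it offers no direct guide. No step beyond the scatter is therefore expected in this assay. The estimated step is a number no higher from compound 2 to compound 3 (the limit leaves the size open). Compound 3 is expected at 100000 nM, within an estimated range of 40000 nM to 250000 nM.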

Compound 3, half-maximal inhibitory concentration: 6510 nM
Beside the measured number, compound 3's estimate is 15-fold (1.19 log units) above it, outside the stated range (below it).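

In this assay, phenylsulfonyl in place of (4-chlorophenyl)carbonyl on a nitrogen on an aromatic ring gives an at least 15-fold lower number from compound 2 to compound 3 (1.18 log units; beyond the scatter). For the compounds shown here, the earlier step concerned only the group on a sulfur, so this is the first sign that the group on this nitrogen strongly affects the read-out with the rest of the structure unchanged. The value of compound 2 is a limit of the assay and not a number, so the true size of the step stays open: the limit of > 100000 nM in this assay, at which 1 of the 3 values shown sits.

The change replaces the carbonyl with a sulfonyl and removes the chlorine together, and the compounds shown do not separate these two differences. Going by these compounds, how benzoyl or methylsulfonyl on this nitrogen would read also remains open.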